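Trimming the Hydrazone Arm of Compound 1

The compounds below may be only part of what the source reports. "The series", "measured", "known", "first", "only" and "open" are said of these compounds alone.

Within the data shown here, compound 1 `C(=N/Nc1nc2ccccc2nc1Cc1ccccc1)\c1ccccc1` gives 81 nM in an assay on isolated protein for inhibition of Amine oxidase [flavin-containing] A (Homo sapiens), read by spectrophotometry (a higher number here means a weaker inhibitor, a lower number a stronger inhibitor), the higher of the two numbers measured so far; compound 2 `O=[N+]([O-])c1ccc(/C=N/Nc2nc3ccccc3nc2Cc2ccccc2)cc1` gives 8.8 nM. Among the measured compounds shown here, the only measured step, a 9.2-fold lower number from compound 1 to compound 2 (0.96 log units; beyond the scatter), shows that a change on that six-membered aromatic ring moves the number well beyond the scatter. Compound 3 `C=NNc1nc2ccccc2nc1Cc1ccccc1` differs from compound 1 by a group of 2 heavy atoms (1 carbon, 1 nitrogen; no ring) in place of a group of 8 heavy atoms (7 carbon, 1 nitrogen; one six-membered aromatic ring of carbon only), on a nitrogen on an aromatic ring. For the measured compounds named here, no measured step removes that ring outright, so the direction rests on the fact that the one substitution on it mattered greatly; the expectation is a clearly weaker inhibitor. Compound 3 is therefore expected to give 2000 nM in this assay, between 400 nM and 10000 nM, a step of a 25-fold higher number from compound 1 to compound 3 (1.39 log units; beyond the scatter).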

Compound 3, half-maximal inhibitory concentration: 86 nM
The estimate for compound 3 lay 23-fold (1.37 log units) above the measured number, and the stated range ends above it.
By their numbers in this assay, from the lowest: compound 2; then compounds 1 and 3 (each within the scatter of the next).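

In this assay, the exchange on a nitrogen on an aromatic ring gives a 1.1-fold higher number from compound 1 to compound 3 (0.03 log units; within the scatter), so the unsubstituted six-membered aromatic ring can give way to a group of 2 heavy atoms with no ring without a change beyond the scatter. The ring's presence alone therefore does not set the number at this position, although the earlier nitro step showed that a substituent on that ring can. Nothing available explains this result.

Still open, from the compounds shown here alone, is how a longer chain in this place would compare with compound 3. Going by these compounds, it is also open whether an amine or a nitrile on the ring would match the nitro group.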